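The source may hold more compounds than are shown below. What is called first, only, known or untested is meant among the compounds shown, and "the series" means these compounds.

Working notes on the series. Among the measured compounds shown here, compound 1 (`O=S(=O)(Nc1ccc(F)c(C#Cc2cnc3[nH]ncc3c2)c1F)c1ccccc1`) and compound 2 (`O=S(=O)(Nc1ccc(F)c(C#Cc2cnc3[nH]ccc3c2)c1F)c1cccnc1`) are the two measured members so far. In a functional assay on COLO 205 cells (Homo sapiens) for antiproliferative activity, read by MTT assay, with a stated time of 68 h (on this read-out higher numbers stand for weaker inhibition and lower numbers for stronger inhibition), compound 1 gives 2100 nM and compound 2 gives 1170 nM on the same read-out, so compound 2 stands within the scatter of compound 1 and the two cannot be ranked. For the measured compounds named here, they differ in more than one place, so the pair offers no single-change step to lean on.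

Compound 3 (`O=S(=O)(Nc1ccc(F)c(C#Cc2cnc3ccnn3c2)c1F)c1cccnc1`) is still unmeasured. Its change from compound 2 lies on a triple-bonded carbon (a group of 9 heavy atoms (6 carbon, 3 nitrogen; one five-membered aromatic ring with 2 hetero atoms, one six-membered aromatic ring with 2 hetero atoms) in place of a group of 9 heavy atoms (7 carbon, 2 nitrogen; one five-membered aromatic ring with 1 hetero atom, one six-membered aromatic ring with 1 hetero atom), on a triple-bonded carbon) and the rest of the structure stays the same. The starting point is compound 2 at 1170 nM in this series, and the direction rests only on a judgement about the change in hydrogen-bond donors, with no measurement behind it yet. The expected move is a 2.6-fold higher number from compound 2 to compound 3 (0.41 log units; beyond the scatter) towards weaker inhibition, an estimate that may not clear the scatter by much. For compound 3 the estimated value is 3000 nM within a range from 1000 nM to 9000 nM in this assay once it is measured.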

Compound 3, half-maximal inhibitory concentration: 1840 nM
The estimate for compound 3 lay 1.6-fold (0.21 log units) above the measured number; the measured number falls inside the stated range.
By their numbers in this assay, from the lowest: compounds 2, 3 and 1 (each within the scatter of the next).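

Among the compounds shown here, this is the first single-change step: on a triple-bonded carbon, a group with 1 hydrogen-bond donor and 1 hydrogen-bond acceptor gives way to one with 0 hydrogen-bond donors and 3 hydrogen-bond acceptors, and this assay records a 1.6-fold higher number from compound 2 to compound 3 (0.20 log units; within the scatter) for this exchange. The read-out therefore does not separate these two groups at this position, even though the hydrogen-bond donor count and the hetero atoms in both rings differ between them, so for this pair the loss of the donor leaves no change that can be read. No supporting measurement is available to explain why the two groups read alike.

From the compounds shown here alone, the pair covers one exchange on one background, so it remains open how a group of another kind, such as a primary amine or a carboxylic acid, would read on the same triple-bonded carbon. Going by these compounds, it also remains open whether the same exchange would stay within the scatter if the rest of the structure were changed, since a single step cannot show whether the result carries over to other members.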